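Swapping the Aryl Group on the Triazole Nitrogen

This account rests on a few compounds, and the source may have more. Where it says the series, first, only, none or still open, it means among the compounds named here.

Among the compounds with values here, compound 3 `N#CC1=C(N)Oc2c(N)cc3nc4ccccc4nc3c2C12C(=O)N(Cc1cnnn1-c1cccc(C(F)(F)F)c1)c1ccccc12` gives 38100 nM in an ADME assay on L02 cells (Homo sapiens) for antiproliferative activity, read by MTT assay, with a stated time of 48 h (on this read-out higher numbers stand for weaker inhibition and lower numbers for stronger inhibition), the only number among the three measured compounds. Compound 1 `CCOc1ccc(-n2nncc2CN2C(=O)C3(C(C#N)=C(N)Oc4c3c3nc5ccccc5nc3c3ccccc43)c3ccccc32)cc1` reaches only the limit > 50000 nM in this assay. Compound 2 `N#CC1=C(N)Oc2c(N)cc3nc4ccccc4nc3c2C12C(=O)N(Cc1cnnn1-c1cccc(Br)c1)c1ccccc12` likewise reaches only the limit > 50000 nM. Two of the three values thus sit at the limit of > 50000 nM in this assay, at which 2 of the 3 values shown sit. Compound 4 `CCc1cccc(C)c1-n1nncc1CN1C(=O)C2(C(C#N)=C(N)Oc3c(N)cc4nc5ccccc5nc4c32)c2ccccc21` carries 2-ethyl-6-methylphenyl in place of 3-(trifluoromethyl)phenyl on an aromatic nitrogen. Within the data shown here, the only measured step at this position, an at least 1.3-fold lower number from compound 2 to compound 3 (0.11 log units; that floor lies within the scatter), stays within the scatter, so in this assay no shift beyond the scatter is expected for compound 4 in either direction, with a real chance that only a limit is reported. Compound 4 is therefore estimated at 40000 nM, between 15000 nM and 100000 nM, which means an expected step of a 1.0-fold higher number from compound 3 to compound 4 (0.02 log units; within the scatter).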

Compound 4, half-maximal inhibitory concentration: > 50000 nM
Compound 4 was reported as a limit; the forecaster's own chance of this, stated with the estimate: 45%; at least 1.2-fold (0.09 log units) between middle value and limit.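

Placing 2-ethyl-6-methylphenyl on this aromatic nitrogen in place of 3-(trifluoromethyl)phenyl gives an at least 1.3-fold higher number from compound 3 to compound 4 (0.11 log units; that floor lies within the scatter), so a second, differently substituted aryl swap also shows no shift beyond the scatter in this assay. The step between compound 2 and compound 4 cannot be read. Compound 4 is a limit, and it joins the other compounds there: the limit of > 50000 nM in this assay, at which 3 of the 4 values shown sit.

Going by these compounds, whether a phenyl group carrying an amine or a carboxylic acid on this nitrogen would move the number beyond the scatter remains open. So does the actual value of compound 4.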